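Bromo to nitro exchange on two cores: working notes

The compounds below may be only part of what the source reports. "The series", "measured", "known", "first", "only" and "open" are said of these compounds alone.

Measured compounds, values in a functional assay on A549 cells (Homo sapiens) for inhibition, read by MTT assay, with a stated time of 48 h; on this read-out lower numbers stand for stronger inhibition and higher numbers for weaker inhibition:
compound 1 `O=[N+]([O-])c1ccc2[nH]cc(C(c3ccc(Br)cc3)c3c[nH]c4ccc([N+](=O)[O-])cc34)c2c1` — > 100000 nM, a limit of the assay
compound 2 `O=[N+]([O-])c1ccc(C(c2c[nH]c3ccc([N+](=O)[O-])cc23)c2c[nH]c3ccc([N+](=O)[O-])cc23)cc1` — > 100000 nM, a limit of the assay
compound 3 `N#Cc1ccc2[nH]cc(C(c3ccc(Br)cc3)c3c[nH]c4ccc(C#N)cc34)c2c1` — > 100000 nM, a limit of the assay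

Three compounds are measured and none gives a number: every value sits at the limit of > 100000 nM in this assay, at which 3 of the 3 values shown sit. Compound 1 and compound 2 share one core and differ only by nitro in place of bromo on an aromatic carbon. Both sit at the limit, so the step that the two limits leave unreadable from compound 1 to compound 2 cannot be read; the change in this assay leaves no readable trace. Compound 3 carries the other core; the difference between the two cores is not broken down here. Compound 3 also only reaches a limit, so the core itself gives no number to compare against.

Compound 4 `N#Cc1ccc2[nH]cc(C(c3ccc([N+](=O)[O-])cc3)c3c[nH]c4ccc(C#N)cc34)c2c1` is not yet measured. It differs from compound 3 by nitro in place of bromo on an aromatic carbon, the same change that is made from compound 1 to compound 2, and the place around it is the same in both pairs. Given that compound 3 sits at the limit in this assay, and that the step that the two limits leave unreadable from compound 1 to compound 2 shows only two limits, the expectation is that compound 4 remains at the limit as well, with an estimated step that the limit leaves unreadable from compound 3 to compound 4 that is itself unreadable. For compound 4 the estimate in this assay is therefore 200000 nM, most likely to be reported as a limit rather than a number.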

Compound 4, half-maximal inhibitory concentration: > 100000 nM
Compound 4: a limit, no number; the forecaster's own chance of this, stated with the estimate: 85%; the middle value is on the limit's open side.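

For the compounds shown here, compound 4 reaches only a limit in this assay, as compound 3 does, so the exchange of bromo for nitro between them gives no readable step, and no new step comes out of this result. All values shown stay at one limit: the limit of > 100000 nM in this assay, at which 4 of the 4 values shown sit.

The compounds shown leave open how large the effect of nitro in place of bromo on inhibition is on either core, or whether there is any.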